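A few compounds are considered here, and "the series" means these few. Any claim that something is new, unique, unknown or untested is made for them only; others in the source may bear on it.

Measured in a functional assay on SW-620 cells (Homo sapiens) for antiproliferative activity, read by MTT assay, with a stated time of 48 h; on this read-out lower numbers stand for stronger inhibition and higher numbers for weaker inhibition:
- Compound 1 `O=C(c1ccc2[nH]c(-c3ccccc3)nc2c1)N1CCC2(CC1)CC(=O)N(c1ccc(C(F)(F)F)cc1)C2`: 2050 nM
- Compound 2 `CC(C)c1ccc(-c2nc3cc(C(=O)N4CCC5(CC4)CC(=O)N(c4ccc(C(F)(F)F)cc4)C5)ccc3[nH]2)cc1`: > 10000 nM, a limit of the assay and not a number
- Compound 3 `O=C(c1ccc2[nH]c(-c3ccncc3)nc2c1)N1CCC2(CC1)CC(=O)N(c1ccc(C(F)(F)F)cc1)C2`: 7240 nM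

Of the two results that are actual numbers, compound 3 has the higher one, and the gap is a 3.5-fold higher number from compound 1 to compound 3 (0.55 log units; beyond the scatter). As far as these compounds go, compound 2 gives only a limit, so the comparison with it is open-ended: an at least 1.3-fold lower number from compound 2 to compound 3 (0.14 log units; that floor lies within the scatter).

Compound 4 `O=C(c1ccc2[nH]c(-c3ccco3)nc2c1)N1CCC2(CC1)CC(=O)N(c1ccc(C(F)(F)F)cc1)C2` carries furan-2-yl in place of pyridin-4-yl on an aromatic carbon.

Among the measured compounds shown here, no measured compound carries furan-2-yl, so the guidance is indirect. The two steps above are the ones that bear on this change, since each swaps the ring at this same place. The clearer one, a 3.5-fold higher number from compound 1 to compound 3 (0.55 log units; beyond the scatter), is modest in size, so only a modest change is expected here. A slight lean towards the lower number of compound 1 is expected, without a step clearly beyond the scatter. The expected step, an estimate, is a 1.8-fold lower number from compound 3 to compound 4 (0.26 log units; within the scatter). For compound 4 the estimated value in this assay is 4000 nM, with an expected range from 1500 nM to 10000 nM.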

Compound 4, half-maximal inhibitory concentration: 3260 nM
Compound 4: middle estimate off by 1.2-fold (0.09 log units), on the high side; measured number inside the range.
By their numbers in this assay, from the lowest: compounds 1 and 4 (each within the scatter of the next); then compound 3. At a limit, above all of these: compound 2.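

Swapping pyridin-4-yl for the smaller furan-2-yl at this place on the shared core gives a real gain in this assay (a 2.2-fold lower number from compound 3 to compound 4 (0.35 log units; beyond the scatter)), so the pyridine ring's weaker result is not shared by every ring with a hetero atom. Set against the plain phenyl ring, furan-2-yl cannot be told apart (a 1.6-fold higher number from compound 1 to compound 4 (0.20 log units; within the scatter)), which shows that a five-membered aromatic ring can stand in for the six-membered one here. As far as these compounds go, compound 2 gives only a limit of the assay and not a number, so its comparison stays open-ended (an at least 3.0-fold lower number from compound 2 to compound 4 (0.48 log units; beyond the scatter)).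

From the compounds shown here alone, how a thiophene ring, or a phenyl ring carrying an amine or a carboxylic acid, would behave at this place remains open. Nothing shown here explains why pyridin-4-yl differs from furan-2-yl and phenyl.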